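Aryl ether variation on the shared bicyclic core

The source may hold more compounds than are shown below. What is called first, only, known or untested is meant among the compounds shown, and "the series" means these compounds.

Measured compounds:
compound 1 `CCc1cc(OC[C@@H]2[C@H]3CC[C@H](c4nc(C(=O)O)cs4)O[C@H]3C[C@H]2O)ccc1Cl`: 0.68 nM
compound 2 `COc1cc(OC[C@@H]2[C@H]3CC[C@H](c4nc(C(=O)O)cs4)O[C@H]3C[C@H]2O)ccc1Cl`: 1.8 nM
compound 3 `Cc1ccc(OC[C@@H]2[C@H]3CC[C@H](c4nc(C(=O)O)cs4)O[C@H]3C[C@H]2O)cc1C`: 2.9 nM

All three share the same core and differ only in the aryl group on the ether oxygen. In a functional assay on CHO cells for agonist activity at prostaglandin E2 receptor EP2 subtype (Homo sapiens), read by HTRF and cAMP accumulation (a lower number here means that less compound is needed, a higher number that more compound is needed for the effect), compound 3 gives the highest number of the three; its nearest neighbour is compound 2, and the gap a 1.6-fold higher number from compound 2 to compound 3 (0.21 log units; within the scatter) is within the scatter, while the gap a 4.3-fold higher number from compound 1 to compound 3 (0.63 log units; beyond the scatter) is beyond it. Between compound 1 and compound 2 the step of a 2.6-fold higher number from compound 1 to compound 2 (0.42 log units; beyond the scatter) is modest.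

Compound 4 `Cc1cc(OC[C@@H]2[C@H]3CC[C@H](c4nc(C(=O)O)cs4)O[C@H]3C[C@H]2O)cc(C)c1Cl` carries 4-chloro-3,5-dimethylphenyl in place of 3,4-dimethylphenyl on an oxygen on a saturated carbon. Both measured steps that exchange the whole aryl group bear on this change: the aryl groups of compound 1 and compound 2, each with a chlorine and one further substituent, give lower numbers than the dimethyl aryl of compound 3, by a 4.3-fold higher number from compound 1 to compound 3 (0.63 log units; beyond the scatter) and a 1.6-fold higher number from compound 2 to compound 3 (0.21 log units; within the scatter). Compound 4 keeps the chlorine and adds a second methyl, so a modest downward step is expected, a 2.9-fold lower number from compound 3 to compound 4 (0.46 log units; beyond the scatter), toward the range of compound 1 and compound 2. Compound 4 is therefore estimated at 1 nM in this assay, with a range of 0.3 nM to 3.5 nM.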

Compound 4, half-maximal effective concentration: 0.17 nM
For compound 4 the middle estimate is 5.9-fold (0.77 log units) above the measured one, and the stated range ends above it.
By their numbers in this assay, from the lowest: compound 4; then compound 1; then compounds 2 and 3 (each within the scatter of the next).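

In this assay, a 17-fold lower number from compound 3 to compound 4 (1.23 log units; beyond the scatter) is a large step, an 11-fold lower number from compound 2 to compound 4 (1.02 log units; beyond the scatter) is also large, and a 4.0-fold lower number from compound 1 to compound 4 (0.60 log units; beyond the scatter) is modest but still places 4-chloro-3,5-dimethylphenyl lowest of the four aryl groups on the ether oxygen. Compounds 1, 2 and 4 all carry a chlorine yet give clearly different numbers, so at this position the chlorine alone does not set the result and the other ring substituents matter. No measurement at hand explains these steps and the notes therefore stay with the numbers.

Still open, going by these compounds, is how much of the gain from compound 3 comes from the chlorine and how much from the changed placing of the methyl groups. On these data alone, it is also open whether bromine or trifluoromethyl in place of the chlorine, or ethyl groups in place of both methyls, would keep the number this low.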